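This account rests on a few compounds, and the source may have more. Where it says the series, first, only, none or still open, it means among the compounds named here.

Compound 1 `O=C(/C=C/c1coc2cc(O)ccc2c1=O)NCc1ccc(F)cc1`: in a functional assay (QGY7701 cells, Homo sapiens) for inhibition, read by MTT assay, with a stated time of 48 h (a higher number here means a weaker inhibitor, a lower number a stronger inhibitor), compound 1 gives > 100000 nM, a limit of the assay.
Compound 2 `COc1ccc2c(=O)c(/C=C/C(=O)Nc3ccc(Cl)cc3)coc2c1`: compound 2 gives > 100000 nM, also a limit.
Compound 3 `Cc1ccc(CNC(=O)/C=C/c2coc3cc(O)ccc3c2=O)cc1`: compound 3 gives 24900 nM.

Compound 2 thus stands at the limit of > 100000 nM in this assay, at which 2 of the 3 values shown sit, with no number of its own. Compound 4 `COc1ccc2c(=O)c(/C=C/C(=O)Nc3ccccc3OC)coc2c1` differs from compound 2 by 2-methoxyphenyl in place of 4-chlorophenyl on an amide-type nitrogen. Among the measured compounds shown here, the only measured step, an at least 4.0-fold lower number from compound 1 to compound 3 (0.60 log units; beyond the scatter), sits on a benzyl-type amide and on a different core, so it does not bear on this change at an amide-type nitrogen carrying an aryl group; no measured step involves the core of compound 2. Compound 4 is therefore expected to show a number no higher from compound 2 to compound 4 (the limit leaves the size open), no step beyond the scatter and most likely again a limit. Compound 4 is estimated at 100000 nM, with a range of 30000 nM to 300000 nM.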

Compound 4, half-maximal inhibitory concentration: 17600 nM
The estimate for compound 4 lay 5.7-fold (0.75 log units) above the measured number; measured number below the stated range.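

In this assay, the aryl group on the amide-type nitrogen of the shared core affects the read-out: 2-methoxyphenyl in place of 4-chlorophenyl gives an at least 5.6-fold lower number from compound 2 to compound 4 (0.75 log units; beyond the scatter). Compound 4 gives this core a measured number rather than only a limit. The value of compound 2 is a limit, so the full size of the step stays open: the limit of > 100000 nM in this assay, at which 2 of the 4 values shown sit.

On these data alone, whether the step follows from the entering methoxy group, its place on the ring or the leaving chloro group remains open. Also open, as far as these compounds go, is how a plain phenyl or a 2-aminophenyl group would read at this nitrogen.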